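The compounds below may be only part of what the source reports. "The series", "measured", "known", "first", "only" and "open" are said of these compounds alone.

In a functional assay on HCT-116 cells (Homo sapiens) for cytotoxicity, read by MTT assay (on this read-out higher numbers stand for weaker inhibition and lower numbers for stronger inhibition), compound 1 `CCCCOC(=O)Nc1ccc(S(=O)(=O)N2C[C@H](c3ccccc3)NC2=O)cc1CC` gives 200 nM, the lowest of the two numbers recorded there. Among the measured compounds shown here, compound 2 `CCc1cc(S(=O)(=O)N2C[C@H](c3ccccc3)NC2=O)ccc1NC(=O)c1ccc([N+](=O)[O-])cc1` gives 500 nM in this assay, and the only one-place step among the measured compounds is a 2.5-fold higher number from compound 1 to compound 2 (0.40 log units; beyond the scatter). Compound 3 `Cc1cc(S(=O)(=O)N2C(=O)N[C@@H](c3ccccc3)C2C)ccc1NC(=O)c1ccc(N)cc1` returns only a limit in this assay, > 10000 nM. That reading is the limit of > 10000 nM in this assay, at which 1 of the 3 values shown sits, so compound 3 adds no number to compare.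

Compound 4 `CCc1cc(S(=O)(=O)N2C[C@H](c3ccccc3)NC2=O)ccc1NC(=O)NC1CCCCC1` has not yet been measured in this assay. It differs from compound 1 in a single place: cyclohexylamino in place of butoxy on a carbonyl carbon. For the measured compounds named here, the one measured step at that carbonyl carbon swapped butoxy for 4-nitrophenyl and moved the number modestly upward, beyond the scatter; the swap to cyclohexylamino is a different replacement at the same carbon, so it points to the likely direction without fixing the size. One therefore expects a modest rise, a 1.8-fold higher number from compound 1 to compound 4 (0.24 log units; within the scatter), and no more. Compound 4 is thus estimated at 350 nM in this assay, with a plausible range from 120 nM to 1000 nM.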

Compound 4, half-maximal inhibitory concentration: 300 nM
For compound 4 the middle estimate is 1.2-fold (0.07 log units) above the measured one, within the range that was stated.
By their numbers in this assay, from the lowest: compounds 1, 4 and 2 (each within the scatter of the next, the first and the last beyond it). At a limit, above all of these: compound 3.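

In this assay, the carbonyl carbon takes cyclohexylamino in place of butoxy, adding a six-membered non-aromatic ring and a hydrogen-bond donor, with a step that stays inside the scatter: a 1.5-fold higher number from compound 1 to compound 4 (0.18 log units; within the scatter). The swap from the aromatic group gives a 1.7-fold lower number from compound 2 to compound 4 (0.22 log units; within the scatter), so compound 4 sits within the scatter of both neighbouring compounds, even though the step between those two lies beyond it, and this carbon has now carried an open chain, an aromatic ring and a non-aromatic ring. Nothing shown gives a cause for these steps.

On these data alone, it remains open whether phenylamino, which would replace the cyclohexyl ring with an aromatic one, would stay within this span at the same carbon. The same holds for a group carrying a carboxylic acid or a basic amine, such as 2-(dimethylamino)ethylamino.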